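A few compounds are considered here, and "the series" means these few. Any claim that something is new, unique, unknown or untested is made for them only; others in the source may bear on it.

Working notes on the series. The read-out throughout is a functional assay for inhibition, with Homo sapiens as the target; on this read-out lower numbers stand for stronger inhibition and higher numbers for weaker inhibition. Compound 2 `CCCc1nc(Br)c2c(Br)nnc(O)n12` stands at the top of the two numbers obtained so far: in this assay compound 2 gives 48000 nM. The nearest number belongs to compound 1 `CC(C)(C)c1nc(Br)c2cnnc(O)n12`, which in this assay gives 19000 nM, and the gap between compound 1 and compound 2 lies beyond the scatter. Within the data shown here, compound 1 and compound 2 differ in more than one place, so no single step between them can be read off.

Compound 3 `CCCc1nc(Br)c2cnnc(O)n12` is not yet measured. It follows from compound 2 by one change: hydrogen in place of bromo on an aromatic carbon. No measured pair in the series isolates this change, so any expectation rests on the two numbers shown. Both sit at the weak end of the scale, and compound 2, which carries the bromo that is removed, holds the higher of them. A modest move toward stronger inhibition is expected, though not one that clearly exceeds the scatter. The expected step is a 1.6-fold lower number from compound 2 to compound 3 (0.20 log units; within the scatter). For compound 3 the estimate in this assay is 30000 nM, with a range from 12000 nM to 80000 nM.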

Compound 3, half-maximal inhibitory concentration: > 48000 nM
Compound 3 ended at the assay's limit; the forecaster's own chance of this, stated with the estimate: 20%; at least 1.6-fold (0.20 log units) between middle value and limit.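

The reading of compound 3 in this assay is a limit of the assay and not a number: the limit of > 48000 nM in this assay, at which 1 of the 3 values shown sits. With hydrogen in place of bromo on this aromatic carbon, para to a hydroxy group, the series shows a number no lower from compound 2 to compound 3 (the limit leaves the size open), so no gain in inhibition appears and removing the bromo does not move compound 3 toward the stronger end of the scale. Among these compounds, the same compound also gives the series its first comparison at the other position: propyl in place of tert-butyl gives an at least 2.5-fold higher number from compound 1 to compound 3 (0.40 log units; beyond the scatter), which places the tert-butyl compound on the side of stronger inhibition and gives the first evidence that this group matters to the read-out.

Going by these compounds, how far compound 3 lies past the limit remains open, and with it the true size of both steps. Also open, on these data alone, is whether an amine, a carboxylic acid or a longer chain on either of these aromatic carbons would bring inhibition away from the weak end of the scale.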